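Swapping a ring on the shared core

The source may hold more compounds than are shown below. What is called first, only, known or untested is meant among the compounds shown, and "the series" means these compounds.

Compound 1, `O=C(CSc1nnc(-c2ccncc2)o1)N/N=C/c1ccccc1`: 17300 nM
Compound 2, `O=C(CSc1nnc(-c2ccncc2)o1)N/N=C/c1ccccc1O`: 3510 nM

In a functional assay on HepG2 cells (Homo sapiens) for cytotoxicity, read by MTT assay, with a stated time of 48 h (on this read-out higher numbers stand for weaker inhibition and lower numbers for stronger inhibition), compound 2 gives the lower of the two numbers, set apart from compound 1 by a 4.9-fold lower number from compound 1 to compound 2 (0.69 log units; beyond the scatter). Compound 3, `O=C(CSc1nnc(-c2ccncc2)o1)N/N=C/c1cccs1`, differs from compound 2 by thiophen-2-yl in place of 2-hydroxyphenyl on a carbon with a double bond to nitrogen. Among the compounds with values here, only one measured step bears on this change: it added the hydroxy that compound 3 now gives up, and it was a 4.9-fold lower number from compound 1 to compound 2 (0.69 log units; beyond the scatter). A step of roughly that size in the opposite direction is therefore expected. Compound 3 is estimated at 12000 nM in this assay, between 4000 nM and 35000 nM. The expected step is a 3.4-fold higher number from compound 2 to compound 3 (0.53 log units; beyond the scatter).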

Compound 3, half-maximal inhibitory concentration: 14900 nM
The estimate for compound 3 lay 1.2-fold (0.09 log units) below the measured number, within the range that was stated.
By their numbers in this assay, from the lowest: compound 2; then compounds 3 and 1 (each within the scatter of the next).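

In this assay, thiophen-2-yl in place of 2-hydroxyphenyl gives a 4.2-fold higher number from compound 2 to compound 3 (0.63 log units; beyond the scatter), while thiophen-2-yl in place of phenyl gives a 1.2-fold lower number from compound 1 to compound 3 (0.06 log units; within the scatter). On this carbon with a double bond to nitrogen, the thiophen-2-yl and phenyl rings therefore cannot be told apart, and among these three compounds only the 2-hydroxyphenyl group stands out. No measurement shown here explains this result. Still open, from the compounds shown here alone, is whether a methoxy or an amine in place of the hydroxy on the phenyl ring would keep the lower number, and whether a hydroxy on the thiophen-2-yl ring would lower it too.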